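This account rests on a few compounds, and the source may have more. Where it says the series, first, only, none or still open, it means among the compounds named here.

In a functional assay on HCT-116 cells (Homo sapiens) for antiproliferative activity, read by MTT assay, with a stated time of 72 h (a higher number here means a weaker inhibitor, a lower number a stronger inhibitor), three compounds have been measured so far:

Compound 1, `C=CC(=O)Nc1nc(-c2ccccc2)cs1`: 18600 nM
Compound 2, `C=CC(=O)Nc1nc(-c2ccc(OC)cc2)cs1`: 8000 nM
Compound 3, `C=CC(=O)N(Cc1cc(C)no1)c1nc(-c2ccccc2)cs1`: a limit of the assay, > 30000 nM

Compound 1 `C=CC(=O)Nc1nc(-c2ccccc2)cs1` is the starting point of the set. Compound 2 differs from it in one place, (methoxy in place of hydrogen on an aromatic carbon), and this change gave a 2.3-fold lower number from compound 1 to compound 2 (0.37 log units; beyond the scatter). Compound 3 differs from compound 1 in another place, ((3-methyl-1,2-oxazol-5-yl)methyl in place of hydrogen on an amide-type nitrogen), and the step of an at least 1.6-fold higher number from compound 1 to compound 3 (0.20 log units; that floor lies within the scatter) is read against a value that is only a limit. For compound 3 the number recorded is the limit of > 30000 nM in this assay, at which 1 of the 3 values shown sits, so its true value is not known.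

Compound 4 `C=CC(=O)N(Cc1cc(C)no1)c1nc(-c2ccccc2OC)cs1` has not yet been measured. It differs from compound 3 by methoxy in place of hydrogen on an aromatic carbon. Among the compounds with values here, this is the same kind of change as the one from compound 1 to compound 2, but the two places are not identical: in compound 2 the methoxy sits "para to a large group", in compound 4 it sits "ortho to a large group".

For compound 4 a step of about an at least 1.2-fold lower number from compound 3 to compound 4 (0.07 log units; that floor lies within the scatter) is expected, resting on the earlier step of a 2.3-fold lower number from compound 1 to compound 2 (0.37 log units; beyond the scatter) in this assay, with the caution that the earlier change sat at a different place and that compound 3 itself gave only a limit. The estimate for compound 4 is therefore 25000 nM, within a range from 9000 nM to 60000 nM.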

Compound 4, half-maximal inhibitory concentration: > 30000 nM
Compound 4: a limit, no number; the forecaster's own chance of this, stated with the estimate: 60%; at least 1.2-fold (0.07 log units) between middle value and limit.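

In this assay compound 4 gives > 30000 nM, which is a limit of the assay and not a number. Compound 3 stands at the same limit, so no step can be read from compound 3 to compound 4: the limit of > 30000 nM in this assay, at which 2 of the 4 values shown sit.

The compounds shown leave open whether methoxy ortho to a large group changes the number at all when (3-methyl-1,2-oxazol-5-yl)methyl sits on the amide-type nitrogen.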